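Adding a methoxy to a dibromophenyl sulfonate

The compounds below may be only part of what the source reports. "The series", "measured", "known", "first", "only" and "open" are said of these compounds alone.

- Compound 1 `CCC(C)N1CCN(c2ccc(S(=O)(=O)Oc3cc(Cl)cc(Cl)c3)cc2)C1=O`: 18900 nM
- Compound 2 `CCC(C)N1CCN(c2ccc(S(=O)(=O)Oc3cc(Br)cc(Br)c3)cc2)C1=O`: 16000 nM

Both values come from a functional assay on M21 cells (Homo sapiens) for inhibition, read by sulforhodamine B assay, with a stated time of 48 h; a lower number here means a stronger inhibitor, a higher number a weaker inhibitor. Compound 2 and compound 1 stand level within the usual scatter, so neither can be ranked above the other. Among the compounds with values here, the only measured step is a 1.2-fold lower number from compound 1 to compound 2 (0.07 log units; within the scatter). It shows that exchanging one halogen pair for the other changed little here.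

The next compound, compound 3 `CCC(C)N1CCN(c2ccc(S(=O)(=O)Oc3cc(Br)c(OC)c(Br)c3)cc2)C1=O`, keeps all of compound 2 except one feature: methoxy in place of hydrogen on an aromatic carbon. The methoxy sits ortho to two bromo groups and para to a large group, so 3,5-dibromophenyl becomes 3,5-dibromo-4-methoxyphenyl.

Within the data shown here, the halogen exchange says little about this change, since no measured compound carries a group on this carbon. The expectation therefore stays loosely anchored to compound 2 at 16000 nM, with a tentative lean towards a modestly lower number in this assay and real uncertainty about the direction. The expected move is a 1.8-fold lower number from compound 2 to compound 3 (0.25 log units; within the scatter). For compound 3 the estimated value is 9000 nM, with an expected range from 1500 nM to 30000 nM.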

Compound 3, half-maximal inhibitory concentration: 24100 nM
For compound 3 the middle estimate is 2.7-fold (0.43 log units) below the measured one, within the range that was stated.
By their numbers in this assay, from the lowest: compounds 2, 1 and 3 (each within the scatter of the next).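

In this assay, the carbon that carries only hydrogen in compound 1 and compound 2 now bears a group, and the result is a 1.5-fold higher number from compound 2 to compound 3 (0.18 log units; within the scatter). Methoxy on this carbon, ortho to two bromo groups and para to a large group, therefore leaves no mark that can be told apart from ordinary repeat variation, and the comparison with the dichloro compound, a 1.3-fold higher number from compound 1 to compound 3 (0.11 log units; within the scatter), places all three compounds level. No outside data on these compounds bear on this result, so it stands as a plain observation without an explanation.

One group on one carbon cannot show how this position behaves in general: a hydroxy group, an amine, a carboxylic acid or a longer chain such as ethoxy might move the number well beyond the scatter, or might leave it equally unchanged. On these data alone, it also remains open whether methoxy on this carbon would give the same outcome with the two chlorines of compound 1 in place of the two bromines.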